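Series notes: chloro for methoxy on the pendant phenyl

The source may report more compounds than this note shows. Statements on the series, on what has been measured and on what is new or still open speak of the compounds shown alone.

Measured so far:
compound 1 `COc1ccc(C(C)NC(=O)/N=C(\N)NCCCc2sc(N)nc2C)cc1` 38 nM
compound 2 `Cc1nc(N)sc1CCCN/C(N)=N/C(=O)NC(c1ccccc1)C(C)C` 34.7 nM
compound 3 `Cc1nc(N)sc1CCCN/C(N)=N/C(=O)NC(c1ccccc1)c1ccccc1` 39.8 nM

The three measured compounds share one core and differ only in the group carried on the saturated carbon bound to the amide-type nitrogen. In a functional assay on Right cardiac atrium for agonist activity at histamine H2 receptor (Cavia porcellus), with a stated time of 30 min, in the presence of a further agent that is not named here (a higher number here means that more compound is needed for the effect, a lower number that less compound is needed), compound 1 gives 38 nM, the second highest of the three numbers, yet within the scatter of both compound 3 and compound 2. For the measured compounds named here, the one single-point step available, a 1.1-fold higher number from compound 2 to compound 3 (0.06 log units; within the scatter), shows that exchanging the group on that carbon hardly moves the read-out.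

Compound 4 `Cc1nc(N)sc1CCCN/C(N)=N/C(=O)NC(C)c1ccc(Cl)cc1` is the next compound. It differs from compound 1 by chloro in place of methoxy on an aromatic carbon. Going by the values given here, no measured pair addresses an exchange on the aromatic ring itself, so the step from compound 2 to compound 3 bears on it only indirectly, as a sign that this region of the molecule tolerates change. With that limited basis, the expected step is a 1.1-fold lower number from compound 1 to compound 4 (0.02 log units; within the scatter), that is, no step beyond the scatter. For compound 4 the estimate in this assay is 36 nM, with an expected range from 15 nM to 90 nM.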

Compound 4, half-maximal effective concentration: 24.6 nM
Beside the measured number, compound 4's estimate is 1.5-fold (0.17 log units) above it; measured number inside the range.
By their numbers in this assay, from the lowest: compounds 4, 2, 1 and 3 (each within the scatter of the next).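

For the compounds shown here, the 4-methoxyphenyl to 4-chlorophenyl exchange gives the first direct reading on the aromatic ring itself: in this assay it gives a 1.5-fold lower number from compound 1 to compound 4 (0.19 log units; within the scatter) and so stays within the scatter. At this place, on an aromatic carbon para to a large group, the hydrogen-bond acceptor of methoxy can therefore be lost in this one pair without a step beyond the scatter, which extends the tolerance seen so far from the saturated carbon to the ring. Nothing available on either group accounts for this reading.

From the compounds shown here alone, whether an amine, a carboxylic acid or a trifluoromethyl at the same ring place would also stay within the scatter remains open. Also open, going by these compounds, is whether the chloro for methoxy exchange would read the same with the isopropyl of compound 2 or the phenyl of compound 3 on the saturated carbon.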